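The compounds below may be only part of what the source reports. "The series", "measured", "known", "first", "only" and "open" are said of these compounds alone.

Of the compounds shown here, three sharing one core have been tested in a functional assay on T47D cells (Homo sapiens) for inhibition, read by CCK-8 assay, with a stated time of 72 h, tested at 10 uM; a lower number here means less inhibition of growth, a higher number more inhibition of growth at the concentration tested. In that test compound 1 `Cc1cccc(NC(=O)C2(C(=O)Nc3ccc(Nc4ncc5cc(C(=O)N(C)C)n(C6CCCC6)c5n4)cc3)CC2)c1` gives 95.3%, compound 2 `CN(C)C(=O)c1cc2cnc(Nc3ccc(NC(=O)C4(C(=O)Nc5ccccc5F)CC4)cc3)nc2n1C1CCCC1` gives 97.8%, and compound 3 `CN(C)C(=O)c1cc2cnc(Nc3ccc(NC(=O)C4(C(=O)Nc5cccc(Cl)c5)CC4)cc3)nc2n1C1CCCC1` gives 92.6%. Compound 3 therefore cannot be told apart from the other two: the data show a number 2.7 percentage points lower from compound 1 to compound 3 (within the scatter) and a number 5.2 percentage points lower from compound 2 to compound 3 (within the scatter).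

Compound 4 `CN(C)C(=O)c1cc2cnc(Nc3ccc(NC(=O)C4(C(=O)Nc5cccc(C(F)(F)F)c5)CC4)cc3)nc2n1C1CCCC1` brings one change to compound 3: trifluoromethyl in place of chloro on an aromatic carbon. In words, trifluoromethyl stands in place of chloro on an aromatic carbon, meta to a large group. Going by the values given here, no tested compound carries trifluoromethyl, so only neighbouring swaps can guide the expectation. The closest is chloro in place of methyl, which gave a number 2.7 percentage points lower from compound 1 to compound 3 (within the scatter). Changing the aryl group on the amide nitrogen gave a number 2.5 percentage points higher from compound 1 to compound 2 (within the scatter). Neither step stands out, so no step beyond the scatter is expected in this assay. The estimate amounts to an expected a number 0.4 percentage points higher from compound 3 to compound 4 (within the scatter). For compound 4 the expected value is 93%, within an estimated range of 84% to 100%.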

Compound 4, percent growth inhibition at one concentration: 92.7%
The estimate for compound 4 lay 0.3 percentage points above the measured number, within the range that was stated.
By their numbers in this assay, from the lowest: compounds 3, 4, 1 and 2 (each within the scatter of the next).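

In this assay, replacing chloro, with 1 heavy atom, by trifluoromethyl, with 4 heavy atoms, at this spot on the aromatic ring gives a number 0.1 percentage points higher from compound 3 to compound 4 (within the scatter), so this larger group fits the series without a visible penalty at the concentration tested. The comparisons with the other two compounds agree, with a number 2.6 percentage points lower from compound 1 to compound 4 (within the scatter) and a number 5.1 percentage points lower from compound 2 to compound 4 (within the scatter), so methyl, chloro and trifluoromethyl at this position, and the 2-fluorophenyl group of compound 2, cannot be told apart here. Nothing available explains why these swaps leave the number in place. From the compounds shown here alone, it remains open whether a group of another kind at this position, such as an amine or a carboxylic acid, would move the number beyond the scatter. A single concentration also cannot show whether these four compounds would separate at lower concentrations.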